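Adding a Methyl Group Beside the Terminal Amine

This account rests on a few compounds, and the source may have more. Where it says the series, first, only, none or still open, it means among the compounds named here.

Measured so far:
- Compound 1, `CC(C)[C@H](NC(=O)CCN(C)C)c1cccc(F)c1N1CCN(C(=O)[C@@H]2CN(C(C)C)C[C@H]2c2cc(F)ccc2F)CC1`: 2050 nM
- Compound 2, `Cc1ccc(N2CCN(C(=O)[C@@H]3CN(C4CCOCC4)C[C@H]3c3ccc(Cl)cc3)CC2)c([C@@H](NC(=O)CCN)C(C)C)c1`: 2.2 nM
- Compound 3, `Cc1ccc(N2CCN(C(=O)[C@@H]3CN(C4CCOCC4)C[C@H]3c3ccc(Cl)cc3)CC2)c([C@@H](NC(=O)CN)C(C)C)c1`: 2 nM

In an assay on HEK293 cells for displacement of a labelled ligand from Melanocortin receptor 4 (Homo sapiens) (a higher number here means a weaker inhibitor, a lower number a stronger inhibitor), compound 3 gives 2 nM, the lowest of the three numbers. Compound 2, at 2.2 nM, sits within the scatter of it, so the two cannot be told apart; compound 1, at 2050 nM, lies far beyond the scatter and is clearly a weaker inhibitor.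

Compound 4, `Cc1ccc(N2CCN(C(=O)[C@@H]3CN(C4CCOCC4)C[C@H]3c3ccc(Cl)cc3)CC2)c([C@@H](NC(=O)[C@H](C)N)C(C)C)c1`, differs from compound 3 by a single change: methyl in place of hydrogen on a saturated chain carbon bound to an amine nitrogen and a carbonyl carbon.

Within the data shown here, the one measured step, a 1.1-fold lower number from compound 2 to compound 3 (0.04 log units; within the scatter), shortened the chain carrying the amine and left the number essentially unchanged. Among the measured compounds shown here, no measured pair tests a methyl on that chain carbon, so the closest guide is that small alterations at this part of the molecule have so far stayed within the scatter. The expected step of a 1.3-fold higher number from compound 3 to compound 4 (0.10 log units; within the scatter) is therefore small, with no clear direction. Compound 4 is estimated at 2.5 nM in this assay, with a range from 0.9 nM to 7 nM.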

Compound 4, inhibition constant: 1 nM
The estimate for compound 4 lay 2.5-fold (0.40 log units) above the measured number; measured number inside the range.
By their numbers in this assay, from the lowest: compounds 4, 3 and 2 (each within the scatter of the next, the first and the last beyond it); then compound 1.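

In this assay a methyl on this saturated chain carbon bound to an amine nitrogen and a carbonyl carbon is tolerated: the change gives a 2.0-fold lower number from compound 3 to compound 4 (0.30 log units; within the scatter) and so leaves compound 3 and compound 4 indistinguishable. Placing 1-aminoethyl in place of 2-aminoethyl on the carbonyl carbon gives a 2.2-fold lower number from compound 2 to compound 4 (0.34 log units; beyond the scatter) and is the only step among these close relatives to pass the scatter, though only modestly. No supporting measurement explains either step.

Going by these compounds, it remains open whether a larger group on that carbon, such as an ethyl or a second methyl, would keep the number this low. The mirror-image arrangement of the methyl and amine on that carbon is also an open question.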